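A Nitrogen Link Returns: From Compound 3 to Compound 4

The compounds below may be only part of what the source reports. "The series", "measured", "known", "first", "only" and "open" are said of these compounds alone.

Compound 1, `COc1cnc(-c2ccccn2)nc1NCc1ccccc1C(F)(F)F`: 230 nM
Compound 2, `COc1cnc(-c2ccccn2)nc1N1CCCCCC1`: 690 nM
Compound 3, `COc1cnc(-c2ccccn2)nc1C1CCCC1`: 1800 nM

Of the compounds shown here, three sharing one core have been measured in a functional assay on RAW264.7 cells (Mus musculus), with a stated time of 3 days; a lower number here means a stronger inhibitor, a higher number a weaker inhibitor. Compound 3 stands at the top of the three numbers, the weakest inhibitor of the set: compound 2 lies at 690 nM and compound 1 at 230 nM, both steps to compound 3 being beyond the scatter.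

Compound 4, `COc1cnc(-c2ccccn2)nc1NC1CCCC1`, is the next compound to be measured. Its change from compound 3 is cyclopentylamino in place of cyclopentyl on an aromatic carbon.

For the measured compounds named here, only one measured step bears on this change: a 2.6-fold higher number from compound 2 to compound 3 (0.42 log units; beyond the scatter). There, an azepan-1-yl attached through its nitrogen gave way to a carbon-attached cyclopentyl, and the number rose modestly. Compound 4 reverses the sense of that step, returning a nitrogen-linked ring while keeping the five-membered ring of compound 3. Compound 1, with a nitrogen-linked benzylic group, gives 230 nM, the lowest of the three, which points the same way. A modest fall in number beyond the scatter is therefore expected, roughly undoing the step from compound 2 to compound 3.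

Compound 4 is estimated to give 650 nM in this assay, within a range of 250 nM to 1600 nM, the expected step being a 2.8-fold lower number from compound 3 to compound 4 (0.44 log units; beyond the scatter).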

Compound 4, half-maximal inhibitory concentration: 570 nM
The estimate for compound 4 lay 1.1-fold (0.06 log units) above the measured number; measured number inside the range.
By their numbers in this assay, from the lowest: compound 1; then compounds 4 and 2 (each within the scatter of the next); then compound 3.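

In this assay, the cyclopentyl ring stays the same while a nitrogen link is added between it and the aromatic carbon, giving a 3.2-fold lower number from compound 3 to compound 4 (0.50 log units; beyond the scatter) for this single change. This separates the link from ring size, which the earlier step from compound 2 to compound 3 could not do, as azepan-1-yl and cyclopentyl differ in both ring and attachment. With nitrogen attachment kept, exchanging azepan-1-yl for cyclopentylamino gives a 1.2-fold lower number from compound 2 to compound 4 (0.08 log units; within the scatter), so these two nitrogen-attached groups cannot be told apart in this assay, and no measurement available here explains why the nitrogen link matters.

The compounds shown leave open whether the link's nitrogen must keep its hydrogen, which an N-methylcyclopentylamino group would test, and whether an oxygen link, as in cyclopentyloxy, would serve in the same way. They also leave open how much of the value of compound 1, at 230 nM, comes from its benzyl ring or its trifluoromethyl group, a question that benzylamino without the trifluoromethyl group would address.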